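Swapping the amine on the aryl amide of compound 1

The source may report more compounds than this note shows. Statements on the series, on what has been measured and on what is new or still open speak of the compounds shown alone.

Measured compounds:
compound 1, `CN(C)CCN(CCN(C)C)c1ccc(C(=O)N2CCc3ccc(OS(N)(=O)=O)cc3C2)cc1`, 15.9%
compound 2, `CCN(Cc1ccccc1)c1cccc(C(=O)N2CCc3ccc(OS(N)(=O)=O)cc3C2)c1`, 69%

In an assay on HEK293 cells for inhibition of Steryl-sulfatase (Homo sapiens), tested at 1 uM (a higher number here means a stronger effect of the compound at the concentration tested, a lower number a weaker effect), compound 1 gives 15.9%, the lowest of the two numbers shown. Compound 2 gives 69%, a reading that lies beyond the scatter above compound 1; compound 2 carries a benzyl(ethyl)amino group in place of the bis(2-(dimethylamino)ethyl)amino of compound 1, though at a different attachment on its ring.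

The next compound, compound 3, `CCN(Cc1ccccc1)c1ccc(C(=O)N2CCc3ccc(OS(N)(=O)=O)cc3C2)cc1`, has not yet been measured. It differs from compound 1 in one place: benzyl(ethyl)amino in place of bis(2-(dimethylamino)ethyl)amino on an aromatic carbon. Since the same benzyl(ethyl)amino group in compound 2 goes with the higher reading of 69%, compound 3 is expected to move upward from compound 1 by a step beyond the scatter, estimated as a number 39.1 percentage points higher from compound 1 to compound 3 (beyond the scatter). For compound 3 the expected value in this assay is 55%, with a range from 30% to 80%.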

Compound 3, a percentage reported as inhibition, at one concentration (the size of the read-out at that concentration, not a potency): 83.6%
Compound 3: middle estimate off by 28.6 percentage points, on the low side, outside the stated range (above it).
By their numbers in this assay, from the lowest: compound 1; then compound 2; then compound 3.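

In this assay, placing benzyl(ethyl)amino in place of bis(2-(dimethylamino)ethyl)amino on an aromatic carbon, para to a large group, gives a number 67.7 percentage points higher from compound 1 to compound 3 (beyond the scatter). Unlike the earlier comparison, in which the attachment on the ring also differed, this step isolates the change of amine at this one position and shows that the reading here depends strongly on that group. The exchange removes a group with three nitrogens and no ring and introduces one with a single nitrogen and an aromatic ring, and nothing measured here explains the step.

The compounds shown leave open which part of the exchange carries the step, since neither diethylamino, without the aromatic ring, nor a single 2-(dimethylamino)ethyl chain appears among them. As far as these compounds go, whether a propyl chain in place of the ethyl would keep the reading also remains open.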